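Swapping isopropyl for iodo on a sulfonate ester scaffold

The compounds below may be only part of what the source reports. "The series", "measured", "known", "first", "only" and "open" are said of these compounds alone.

Four closely related sulfonate esters are compared here. Compound 1 `CC(=O)Nc1ccc(S(=O)(=O)Oc2ccccc2C(C)C)cc1` and compound 2 `CC(=O)Nc1ccc(S(=O)(=O)Oc2ccccc2I)cc1` share an acetamido group; compound 3 `CCCNC(=O)Nc1ccc(S(=O)(=O)Oc2ccccc2C(C)C)cc1` and compound 4 `CCCNC(=O)Nc1ccc(S(=O)(=O)Oc2ccccc2I)cc1` carry a propylcarbamoylamino group in its place. In a functional assay on HT-29 cells (Homo sapiens) for antiproliferative activity, read by sulforhodamine B assay, with a stated time of 48 h (a lower number here means a stronger inhibitor, a higher number a weaker inhibitor), compound 1 gives 23000 nM, and compound 2 gives 23000 nM. The change between them, (iodo in place of isopropyl on an aromatic carbon), produced no change at the digits printed from compound 1 to compound 2 (within the scatter). The two cores differ by propylamino in place of methyl on a carbonyl carbon, and that change gave a 3.7-fold lower number from compound 1 to compound 3 (0.56 log units; beyond the scatter), so compound 3, at 6300 nM, has the lowest number of the three measured compounds.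

Compound 4 is not yet measured. It differs from compound 3 by iodo in place of isopropyl on an aromatic carbon, the same change that was made from compound 1 to compound 2, at the same place on the ring. Among the measured compounds shown here, since that earlier step was flat, the step from compound 3 to compound 4 is expected to be similar, about no change at the digits printed from compound 3 to compound 4 (within the scatter), resting on the single precedent of no change at the digits printed from compound 1 to compound 2 (within the scatter). Compound 4 is therefore estimated at 6300 nM, most likely between 3000 nM and 13000 nM in this assay.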

Compound 4, half-maximal inhibitory concentration: 6800 nM
Compound 4: the middle estimate sits 1.1-fold (0.03 log units) below what was measured; low and high end bracket the measured number.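

In this assay, swapping isopropyl for iodo again leaves the number in place, with a 1.1-fold higher number from compound 3 to compound 4 (0.03 log units; within the scatter), and the step on this core matches the one on the core of compound 1: the same change on two cores in this assay, no change at the digits printed (within the scatter) from compound 1 to compound 2 and a 1.1-fold higher number (0.03 log units; within the scatter) from compound 3 to compound 4, 1.1-fold (0.03 log units) apart, within the scatter of two such steps. The other change, propylamino in place of methyl on a carbonyl carbon, also carries over, giving a 3.4-fold lower number from compound 2 to compound 4 (0.53 log units; beyond the scatter) on the iodo compounds, close to the step seen on the isopropyl compounds: the same change on two cores in this assay, a 3.7-fold lower number (0.56 log units; beyond the scatter) from compound 1 to compound 3 and a 3.4-fold lower number (0.53 log units; beyond the scatter) from compound 2 to compound 4, 1.1-fold (0.03 log units) apart, within the scatter of two such steps. Across these four compounds the two changes therefore act as if each were independent of the other, but this rests on one pair of steps per change in a single cell assay, and it shows neither why the numbers behave this way nor that other groups would follow the same pattern.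

Going by these compounds, it remains open whether other groups at the same place on the ring, such as chloro or methoxy, would also leave the number unchanged. On these data alone, it is equally open whether a longer chain than propyl, such as hexyl, would lower the number further on either core.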